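The source may report more compounds than this note shows. Statements on the series, on what has been measured and on what is new or still open speak of the compounds shown alone.

Compound 1 `COc1ccc(-c2cnc(NC(=O)C3CCCCC3)n2C)cc1`, compound 2 `COc1ccc(-c2cnc(NC(=O)c3cccc(OC)c3)n2C)cc1` and compound 3 `COc1ccc(-c2cnc(NC(=O)CCc3ccccc3)n2C)cc1` share one core and differ only in the group on the carbonyl carbon of the amide. In a toxicity assay on THP-1 cells (Homo sapiens) for inhibition (on this read-out higher numbers stand for lower toxicity in this test and lower numbers for higher toxicity in this test), compound 1 gives > 100000 nM, which is a limit of the test rather than a number. In this assay compound 2 likewise gives only a limit, > 100000 nM. Compound 3 also reaches only a limit in this assay, > 100000 nM. Compound 3 thus stands with the other two at the limit of > 100000 nM in this assay, at which 3 of the 3 values shown sit, and the steps a step that the two limits leave unreadable from compound 1 to compound 2, a step that the two limits leave unreadable from compound 1 to compound 3 and a step that the two limits leave unreadable from compound 2 to compound 3 cannot be sized from these values. Compound 4 `COc1ccc(C(=O)Nc2ncc(-c3ccc(OC)cc3)n2C)cc1` arises from compound 3 through (4-methoxyphenyl in place of phenethyl on a carbonyl carbon). Within the data shown here, since none of the measured steps can be read, there is no ground for expecting a change in either direction beyond the scatter, and all three measured compounds point the same way. Compound 4 is therefore expected to sit at the limit as well, with an estimate of 150000 nM, between 60000 nM and 400000 nM. The expected step that the limit leaves unreadable from compound 3 to compound 4 is thus essentially none.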

Compound 4, half-maximal cytotoxic concentration: > 100000 nM
Compound 4 was reported as a limit (the forecaster's own chance of this, stated with the estimate: 85%); the middle value is on the limit's open side.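

Compound 4 also gives only a limit, so none of the steps joining it to compound 1, compound 2 and compound 3 can be read: the limit of > 100000 nM in this assay, at which 4 of the 4 values shown sit. The compounds shown leave open whether any group on the amide carbonyl carbon changes the result in this assay at all.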